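A swap to 3-(trifluoromethyl)phenyl on compound 1

The source may hold more compounds than are shown below. What is called first, only, known or untested is meant among the compounds shown, and "the series" means these compounds.

Within the data shown here, in a functional assay on B16-BL6 cells (Mus musculus) for cytotoxicity, read by MTT assay, with a stated time of 48 h (on this read-out higher numbers stand for weaker inhibition and lower numbers for stronger inhibition), compound 1 `CNC(=O)c1ccc(Sc2ccc(NC(=S)Nc3ccc(Cl)cc3)cc2)nc1` gives 69300 nM, the only true number among the three compounds measured so far. Compound 2 `CNC(=O)c1ccc(Sc2ccc(NC(=S)Nc3ccc(OC(F)(F)F)cc3)cc2)nc1` reads > 100000 nM, which is a limit of the assay and not a number. Compound 3 `CNC(=O)c1ccc(Sc2cccc(NC(=S)Nc3ccc(Br)c(C(F)(F)F)c3)c2)nc1` reads > 100000 nM, which is also a limit.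

Compound 4 `CNC(=O)c1ccc(Sc2ccc(NC(=S)Nc3cccc(C(F)(F)F)c3)cc2)nc1` changes one part of compound 1: 3-(trifluoromethyl)phenyl takes the place of 4-chlorophenyl on an amide-type nitrogen (3-(trifluoromethyl)phenyl in place of 4-chlorophenyl on an amide-type nitrogen). Among the measured compounds shown here, the only measured single change, an at least 1.4-fold higher number from compound 1 to compound 2 (0.15 log units; that floor lies within the scatter), swaps chloro for trifluoromethoxy on an aromatic carbon, so it offers only a weak hint of a higher number. Compound 3 also carries a trifluoromethyl group, but it differs from compound 1 elsewhere too and is a loose guide at best.

The expected change is small and toward weaker inhibition, perhaps no larger than the scatter: a 1.3-fold higher number from compound 1 to compound 4 (0.11 log units; within the scatter). For compound 4 the estimated value is 90000 nM, with an expected range from 45000 nM to 180000 nM.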

Compound 4, half-maximal inhibitory concentration: 53100 nM
Beside the measured number, compound 4's estimate is 1.7-fold (0.23 log units) above it, within the range that was stated.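

On the amide-type nitrogen, 3-(trifluoromethyl)phenyl can take the place of 4-chlorophenyl with no readable effect in this assay: the step is a 1.3-fold lower number from compound 1 to compound 4 (0.12 log units; within the scatter), so the two values cannot be told apart. Among these compounds, this is the first pair at this position with a true number on both sides, and it shows that this change, which alters both the substituent and its place on the ring, leaves the reading where it was. Compound 2 reads > 100000 nM, which is a limit and not a number, and such limits take up much of this small set: the limit of > 100000 nM in this assay, at which 2 of the 4 values shown sit.

Going by these compounds, whether an amine or a carboxylic acid on this phenyl ring would move the value beyond the scatter remains open. So does the effect of a longer alkyl chain in place of the ring.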